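Thiazolyl in place of pyridinyl: agonist series notes

This account rests on a few compounds, and the source may have more. Where it says the series, first, only, none or still open, it means among the compounds named here.

Measured so far:
compound 1 `Cc1cccc(C(=O)NCN2CCC(c3ccccn3)CC2)c1`: 9 nM
compound 2 `O=C(CN1CCC(c2cccc[n+]2[O-])CC1)Nc1ccc(F)cc1F`: 103 nM

In a functional assay on HEK293 cells for agonist activity at D(4) dopamine receptor (Homo sapiens), read by FLIPR (on this read-out lower numbers stand for an effect already at smaller amounts and higher numbers for an effect only at larger amounts of compound), compound 1 gives 9 nM, the lower of the two numbers. Compound 2 gives 103 nM, a higher number whose gap to compound 1 lies beyond the scatter. Compound 2 differs from compound 1 in several places, so these two values only show where each compound stands; no single step can be read from them.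

Compound 3 `Cc1cccc(C(=O)NCN2CCC(c3nccs3)CC2)c1` has not yet been measured. It differs from compound 1 in one place: 1,3-thiazol-2-yl in place of pyridin-2-yl on a saturated ring carbon. Within the data shown here, no measured pair shows a change of this kind, so the size of the step has no anchor in the data. The expected step of a 2.2-fold higher number from compound 1 to compound 3 (0.35 log units; beyond the scatter) is a modest move toward higher numbers, close to the scatter, keeping compound 3 near the low end of the series. Compound 3 is expected to give 20 nM, with a range from 5 nM to 80 nM.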

Compound 3, half-maximal effective concentration: 9.8 nM
Compound 3: middle estimate off by 2.0-fold (0.31 log units), on the high side, and the stated range covers the measured number.
By their numbers in this assay, from the lowest: compounds 1 and 3 (each within the scatter of the next); then compound 2.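

In this assay, among these compounds, the exchange of pyridin-2-yl for 1,3-thiazol-2-yl on a saturated ring carbon gives a 1.1-fold higher number from compound 1 to compound 3 (0.04 log units; within the scatter) and is the first single-place step. At this place on the core of compound 1, a six-membered aromatic ring with 1 hetero atom and a five-membered aromatic ring with 2 hetero atoms are therefore not told apart by this read-out, and pyridin-2-yl is not needed for a number at the low end of the series. Nothing at hand explains this result.

From the compounds shown here alone, both rings carry a ring nitrogen, so it remains open how phenyl, with no ring nitrogen, or a non-aromatic group such as cyclohexyl would read at this place. Going by these compounds, it is also open whether the same exchange would give a step of similar size on the core of compound 2.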